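Chlorophenyl to Trifluoromethylphenyl on a Shared Core

The source may hold more compounds than are shown below. What is called first, only, known or untested is meant among the compounds shown, and "the series" means these compounds.

Compound 1, `Cc1ccc(-n2nncc2CN2C(=O)C3(C(C#N)=C(N)Oc4c3c3nc5ccccc5nc3c3ccccc43)c3ccccc32)c(C)c1`, gives a limit of > 50000 nM in a functional assay on MCF7 cells (Homo sapiens) for antiproliferative activity, read by MTT assay, with a stated time of 48 h; on this read-out lower numbers stand for stronger inhibition and higher numbers for weaker inhibition.
Compound 2, `Cc1ccccc1-n1nncc1CN1C(=O)C2(C(C#N)=C(N)Oc3c(N)cc4nc5ccccc5nc4c32)c2ccccc21`, gives a limit of > 50000 nM in this assay.
Compound 3, `N#CC1=C(N)Oc2c(N)cc3nc4ccccc4nc3c2C12C(=O)N(Cc1cnnn1-c1ccc(Cl)cc1)c1ccccc12`, gives a limit of > 50000 nM in this assay.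

None of these three values is a number: all sit at the limit of > 50000 nM in this assay, at which 3 of the 3 values shown sit. Compound 3 therefore stands at that limit, without a measurable strength. Going by the values given here, the single step between measured compounds, a step that the two limits leave unreadable from compound 2 to compound 3, cannot be read, as both ends are limits. Compound 4, `N#CC1=C(N)Oc2c(N)cc3nc4ccccc4nc3c2C12C(=O)N(Cc1cnnn1-c1cccc(C(F)(F)F)c1)c1ccccc12`, differs from compound 3 by 3-(trifluoromethyl)phenyl in place of 4-chlorophenyl on an aromatic nitrogen. Among the compounds with values here, no measured step bears on this change, and no direction beyond the scatter can be expected from the values shown. Compound 4 is expected to return a limit as well, with an estimated value of 80000 nM and a range from 30000 nM to 300000 nM, meaning an expected step that the limit leaves unreadable from compound 3 to compound 4.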

Compound 4, half-maximal inhibitory concentration: 31600 nM
Beside the measured number, compound 4's estimate is 2.5-fold (0.40 log units) above it; low and high end bracket the measured number.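

Moving to 3-(trifluoromethyl)phenyl on this aromatic nitrogen gives the first real number at this position, with an at least 1.5-fold lower number from compound 3 to compound 4 (0.19 log units; that floor lies within the scatter). Against 2-methylphenyl the result is an at least 1.5-fold lower number from compound 2 to compound 4 (0.19 log units; that floor lies within the scatter), so both steps are only floors and neither shows a gain beyond the scatter. Every other compound stays at a limit: the limit of > 50000 nM in this assay, at which 3 of the 4 values shown sit.

As far as these compounds go, it remains open whether a phenyl ring carrying an amine or a carboxylic acid at this position would give a number in this assay. From the compounds shown here alone, the true size of both steps also remains unknown.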